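Aryl replacement on compound 2: expectation for compound 4

The source may hold more compounds than are shown below. What is called first, only, known or untested is meant among the compounds shown, and "the series" means these compounds.

For the measured compounds named here, in a functional assay on HuTu80 cells (Homo sapiens) for cytotoxicity, read by MTT assay, with a stated time of 72 h (on this read-out higher numbers stand for an effect only at larger amounts of compound and lower numbers for an effect already at smaller amounts), compound 2 `O=C1/C(=C\c2c(Cl)cccc2Cl)c2ccccc2N1c1c(Cl)cccc1Cl` gives 100 ug/mL, the only plain number in the set. Compound 1 `COc1ccc(/C=C2\C(=O)N(c3c(Cl)cccc3Cl)c3ccccc32)cc1OC` reports < 1 ug/mL, which is a limit of the assay and not a number. Compound 3 `O=C1/C(=C\c2cc3ccccc3nc2Cl)c2ccccc2N1c1c(Cl)cccc1Cl` stands at "not determined" (no result reported) in this assay. Compound 2 is therefore the single fixed point; the other anchor is the limit of < 1 ug/mL in this assay, at which 1 of the 3 values shown sits.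

Compound 4 `O=C1/C(=C\c2ccc(O)cc2)c2ccccc2N1c1c(Cl)cccc1Cl` differs from compound 2 by 4-hydroxyphenyl in place of 2,6-dichlorophenyl on a double-bonded chain carbon bound to a double-bonded ring carbon. Going by the values given here, no measured step covers this change, so the direction is read from the set as a whole. Since compound 1 reaches < 1 ug/mL, a move toward smaller amounts is expected for compound 4. The expected step from compound 2 to compound 4 is a 10-fold lower number from compound 2 to compound 4 (1.00 log units; beyond the scatter), beyond the scatter. Compound 4 is estimated at 10 ug/mL, in a range from 1 ug/mL to 50 ug/mL.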

Compound 4, concentration for half-maximal effect: 25 ug/mL
Compound 4: the middle estimate sits 2.5-fold (0.40 log units) below what was measured; low and high end bracket the measured number.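

In this assay, for the compounds shown here, 4-hydroxyphenyl in place of 2,6-dichlorophenyl on a double-bonded chain carbon bound to a double-bonded ring carbon gives a 4.0-fold lower number from compound 2 to compound 4 (0.60 log units; beyond the scatter), the only readable step at this position. The read-out at this position therefore responds to a change of aryl group, and a phenyl ring without chlorine still gives a plain number. Nothing measured here gives a cause for this step.

Going by these compounds, the loss of both chlorines and the gain of the hydroxyl occur together, so their separate shares in the step remain open. Also open, on these data alone, is how an amine or a carboxylic acid in place of that hydroxyl would read.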